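Amide substituent variation in a stilbene cinnamamide series

The source may hold more compounds than are shown below. What is called first, only, known or untested is meant among the compounds shown, and "the series" means these compounds.

Measured compounds:
compound 1 `CCNC(=O)/C=C/c1c(/C=C/c2ccc(OC)cc2)cc(OC)cc1OC`, 7860 nM
compound 2 `CCC(C)NC(=O)/C=C/c1c(/C=C/c2ccc(OC)cc2)cc(OC)cc1OC`, 3950 nM

In a functional assay on A549 cells (Homo sapiens) for inhibition, read by MTT assay, with a stated time of 48 h (on this read-out higher numbers stand for weaker inhibition and lower numbers for stronger inhibition), compound 1 gives 7860 nM and compound 2 gives 3950 nM. Among the compounds with values here, the single step, a 2.0-fold lower number from compound 1 to compound 2 (0.30 log units; within the scatter), is within the scatter, so the two numbers cannot be ranked against each other; compound 2 simply holds the lower of the two numbers.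

Compound 3 `COc1ccc(/C=C/c2cc(OC)cc(OC)c2/C=C/C(=O)N2CCC(c3ccccc3)CC2)cc1` is not yet measured in this assay. Its change from compound 2 is 4-phenylpiperidin-1-yl in place of (sec-butyl)amino on a carbonyl carbon. Within the data shown here, no measured step covers a change of this kind: the one step in hand only swaps ethyl for hydrogen on the chain bound to the amide nitrogen and stays within the scatter. Nothing in the data therefore points to a step beyond the scatter in either direction, and the expectation for compound 3 in this assay is a number close to that of compound 2, with a wide range to cover the unknown effect of the larger group. The estimated step is a 1.2-fold lower number from compound 2 to compound 3 (0.09 log units; within the scatter). For compound 3 the estimate in this assay is 3200 nM, expected to fall between 800 nM and 13000 nM.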

Compound 3, half-maximal inhibitory concentration: 6690 nM
Compound 3: middle estimate off by 2.1-fold (0.32 log units), on the low side, within the range that was stated.
By their numbers in this assay, from the lowest: compounds 2, 3 and 1 (each within the scatter of the next).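

In this assay, the carbonyl carbon takes 4-phenylpiperidin-1-yl in place of (sec-butyl)amino with a 1.7-fold higher number from compound 2 to compound 3 (0.23 log units; within the scatter) and in place of ethylamino with a 1.2-fold lower number from compound 1 to compound 3 (0.07 log units; within the scatter). Within the data shown here, the step from the earlier compounds is therefore much larger than the ethyl-for-hydrogen swap on the chain: the entering group has 12 heavy atoms and two six-membered rings, and 0 hydrogen-bond donors where the leaving group has 1, yet no step beyond the scatter appears at this position. No measurement here offers an explanation for this result.

On these data alone, whether any group on this carbonyl carbon can move the number beyond the scatter remains open, for example morpholin-4-yl, a piperidine carrying a primary amine, or a chain ending in a carboxylic acid. The compounds shown also share one core, so they say nothing about how its methoxy groups contribute.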